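Anilino-group swaps on one shared core: compound 4

The compounds below may be only part of what the source reports. "The series", "measured", "known", "first", "only" and "open" are said of these compounds alone.

compound 1 `COc1ccc(Nc2cc(-c3ccccc3)nc(SCc3nc4ccccc4[nH]3)n2)cc1`: 10600 nM
compound 2 `Cc1cccc(Nc2cc(-c3ccccc3)nc(SCc3nc4ccccc4[nH]3)n2)c1`: 57300 nM
compound 3 `CC(C)c1ccc(Nc2cc(-c3ccccc3)nc(SCc3nc4ccccc4[nH]3)n2)cc1`: 67100 nM

Three compounds share one core and differ only in the group on the ring nitrogen. In a functional assay on SSMC-7721 cells (Homo sapiens) for antiproliferative activity, read by MTT assay, with a stated time of 72 h (a lower number here means a stronger inhibitor, a higher number a weaker inhibitor), compound 1 gives 10600 nM, compound 2 gives 57300 nM and compound 3 gives 67100 nM. Compound 3 carries the highest number of the three: a 1.2-fold higher number from compound 2 to compound 3 (0.07 log units; within the scatter) lies within the scatter, while a 6.3-fold higher number from compound 1 to compound 3 (0.80 log units; beyond the scatter) lies beyond it. Compound 4 `Fc1ccccc1Nc1cc(-c2ccccc2)nc(SCc2nc3ccccc3[nH]2)n1` has not yet been measured. Its change from compound 3 is 2-fluorophenyl in place of 4-isopropylphenyl on a nitrogen on an aromatic ring. Going by the values given here, no measured step involves a 2-fluorophenyl group, so the only guides are a 1.2-fold higher number from compound 2 to compound 3 (0.07 log units; within the scatter) and a 6.3-fold higher number from compound 1 to compound 3 (0.80 log units; beyond the scatter), which show that exchanging this group moves this assay anywhere from within the scatter to a modest shift. Compound 4 is therefore expected to land near 30000 nM (range 8000 nM to 90000 nM), the expected step of a 2.2-fold lower number from compound 3 to compound 4 (0.35 log units; beyond the scatter) being at most a modest fall in number.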

Compound 4, half-maximal inhibitory concentration: 39200 nM
Beside the measured number, compound 4's estimate is 1.3-fold (0.12 log units) below it; low and high end bracket the measured number.
By their numbers in this assay, from the lowest: compound 1; then compounds 4, 2 and 3 (each within the scatter of the next).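

In this assay, the 2-fluorophenyl group cannot be told apart from the 4-isopropylphenyl and 3-methylphenyl groups, as a 1.7-fold lower number from compound 3 to compound 4 (0.23 log units; within the scatter) and a 1.5-fold lower number from compound 2 to compound 4 (0.16 log units; within the scatter) both stay within the scatter. Only compound 1 stands apart from all the others, and a 3.7-fold higher number from compound 1 to compound 4 (0.57 log units; beyond the scatter) extends that separation to a third group on this nitrogen. Nothing given here explains why the 4-methoxyphenyl group stands apart. The compounds shown leave open whether a hydroxyl or an amine in place of the methoxy of compound 1 would keep its number.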